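The compounds below may be only part of what the source reports. "The series", "measured", "known", "first", "only" and "open" are said of these compounds alone.

Compound 3 `CCCCCCCCOC(=O)CS(=O)(=O)Nc1c(C(C)C)cccc1C(C)C` shares its core with compound 1 `CCCCCCNC(=O)CS(=O)(=O)Nc1c(C(C)C)cccc1C(C)C`, compound 2 `CC(C)c1cccc(C(C)C)c1NS(=O)(=O)CC(=O)N(Cc1ccccc1)C(C)C` and the still unmeasured compound 4 `CCCCCCSC(=O)CS(=O)(=O)Nc1c(C(C)C)cccc1C(C)C`. In an assay on microsomes from intestine for inhibition of acyl-CoA:cholesterol acyltransferase (Oryctolagus cuniculus) (a lower number here means a stronger inhibitor, a higher number a weaker inhibitor), compound 3 gives only a limit, > 1000 nM. Compound 1 likewise gives only a limit, > 5000 nM. Compound 2 gives 150 nM. The step that the two limits leave unreadable from compound 1 to compound 3 cannot be read, because the limit of > 1000 nM in this assay, at which 1 of the 3 values shown sits, and the limit of > 5000 nM in this assay, at which 1 of the 3 values shown sits, both sit at limits rather than at numbers. Compound 4 differs from compound 3 in that (hexylsulfanyl in place of octyloxy on a carbonyl carbon). For the measured compounds named here, no measured step bears directly on this change: the one step on the same carbonyl carbon, from hexylamino to octyloxy, is unreadable, and compound 2 shows only that a differently built amide on this core reaches a measurable number. For compound 4 the change from compound 3 is therefore expected to stay within the scatter, a step that the limit leaves unreadable from compound 3 to compound 4. Compound 4 is thus estimated to give about 3000 nM, with a range from 800 nM to 15000 nM, and quite possibly again only a limit.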

Compound 4, half-maximal inhibitory concentration: 1000 nM
Compound 4: the middle estimate sits 3.0-fold (0.48 log units) above what was measured, and the stated range covers the measured number.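

In this assay, for the compounds shown here, hexylsulfanyl in place of hexylamino on a carbonyl carbon gives an at least 5.0-fold lower number from compound 1 to compound 4 (0.69 log units; beyond the scatter), the first step at this position with a readable size. Both groups carry a hexyl chain, and compound 4 gives a number rather than a limit. Hexylsulfanyl in place of octyloxy on a carbonyl carbon gives a number no higher from compound 3 to compound 4 (the limit leaves the size open), and the size of this step stays open: the limit of > 1000 nM in this assay, at which 1 of the 4 values shown sits.

Octyloxy and hexylsulfanyl differ in both the atom on the carbonyl carbon and the chain, so the effects of those two differences remain tangled. A hexyloxy group or an octylsulfanyl group on the same carbon would separate them and show whether sulfur or chain length matters more here.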